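The source may hold more compounds than are shown below. What is called first, only, known or untested is meant among the compounds shown, and "the series" means these compounds.

Working notes on the series.

Compound 1 `Cc1cc(C(=O)O)c(C)n1-c1cccc(F)c1` and compound 2 `Cc1cc(C(=O)O)c(C)n1-c1ccc(F)cc1` are built from the same atoms joined differently; the difference between the two cores is not broken down here. In an assay on cells for inhibition of Palmitoleoyl-protein carboxylesterase NOTUM variant C330S (Homo sapiens), read by fluorescence, with a stated time of 40 min (on this read-out lower numbers stand for stronger inhibition and higher numbers for weaker inhibition), compound 1 gives 1500 nM and compound 2 gives 1900 nM, values within the scatter of each other. Compound 3 `Cc1cccc(-n2c(C)cc(C(=O)O)c2C)c1` carries methyl in place of fluoro on an aromatic carbon, and in this assay compound 3 gives 1500 nM, so that no change at the digits printed from compound 1 to compound 3 (within the scatter).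

Compound 4 `Cc1ccc(-n2c(C)cc(C(=O)O)c2C)cc1` is not yet measured. It carries methyl in place of fluoro on an aromatic carbon. This is the same kind of change as that from compound 1 to compound 3, but not the same: there the entering methyl sits meta to a large group, here para to a large group. Among the measured compounds shown here, with only one measured instance of this change, and with compound 1 and compound 2 close together, the expectation rests on that single step: because no change at the digits printed from compound 1 to compound 3 (within the scatter), the step from compound 2 to compound 4 is expected to be a 1.1-fold lower number from compound 2 to compound 4 (0.02 log units; within the scatter). For compound 4 in this assay the estimate is 1800 nM, with a range from 900 nM to 3600 nM.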

Compound 4, half-maximal inhibitory concentration: 2000 nM
Compound 4: the middle estimate sits 1.1-fold (0.05 log units) below what was measured; measured number inside the range.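

In this assay, methyl in place of fluoro on the second core gives a 1.1-fold higher number from compound 2 to compound 4 (0.02 log units; within the scatter). Set beside the earlier step, the same change reads alike on the two cores: the same change on two cores in this assay, no change at the digits printed (within the scatter) from compound 1 to compound 3 and a 1.1-fold higher number (0.02 log units; within the scatter) from compound 2 to compound 4, 1.1-fold (0.02 log units) apart, within the scatter of two such steps This shows that, for these two pairs, the exchange of fluoro for methyl carries from one core to the other with no step beyond the scatter; it does not show that the same would hold on any other core, and two steps this small cannot reveal whether a real but small difference between the cores exists.

Still open, on these data alone, is whether another group at these places on the aromatic ring, such as a nitrile, a methoxy, a trifluoromethyl or an amine, would give a step beyond the scatter. Also open, as far as these compounds go, is how the series would respond if the carboxylic acid gave way to an amide or if either methyl on the shared core gave way to a longer chain.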